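Trimming the propyl chain down to methyl

The compounds below may be only part of what the source reports. "The series", "measured", "known", "first", "only" and "open" are said of these compounds alone.

In a functional assay on KB cells (Homo sapiens) for antiproliferative activity, read by sulforhodamine B assay, with a stated time of 48 h (a higher number here means a weaker inhibitor of growth, a lower number a stronger inhibitor of growth), three compounds share one core and differ in the group on a nitrogen on an aromatic ring. Compound 1 `COc1ccc(Nc2nc(NC3CCCC3)c3ccccc3n2)cc1`, with cyclopentyl, gives 11100 nM. Compound 2 `COc1ccc(Nc2nc(NCCCO)c3ccccc3n2)cc1`, with 3-hydroxypropyl, gives 20300 nM. Compound 3 `CCCNc1nc(Nc2ccc(OC)cc2)nc2ccccc12`, with propyl, gives 5330 nM, the lowest number of the three and so the strongest growth inhibitor among them.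

Compound 4 `CNc1nc(Nc2ccc(OC)cc2)nc2ccccc12` has not yet been measured. It differs from compound 3 as follows: hydrogen in place of ethyl on a saturated chain carbon bound to a nitrogen on an aromatic ring. This places hydrogen in place of ethyl on a saturated chain carbon bound to a nitrogen on an aromatic ring, so propyl becomes methyl.

Among the compounds with values here, no measured step shortens a chain, so the evidence is indirect. Within the data shown here, two steps bear on the change: a 2.1-fold lower number from compound 1 to compound 3 (0.32 log units; beyond the scatter), where propyl replaces cyclopentyl, and a 3.8-fold lower number from compound 2 to compound 3 (0.58 log units; beyond the scatter), where hydrogen replaces hydroxy. Both are modest, and in both compound 3 holds the lower number. A small rise in this assay therefore seems more likely than a fall once propyl is lost.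

The estimated outcome is a 1.5-fold higher number from compound 3 to compound 4 (0.18 log units; within the scatter), a modest step that may not clear the usual scatter. For compound 4 the expected value is 8000 nM, with an estimated range from 3000 nM to 22000 nM.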

Compound 4, concentration for 50% growth inhibition: 14800 nM
Compound 4: the middle estimate sits 1.9-fold (0.27 log units) below what was measured, within the range that was stated.
By their numbers in this assay, from the lowest: compound 3; then compounds 1, 4 and 2 (each within the scatter of the next).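

Within this assay, this is the first step that changes only the length of a plain chain on this nitrogen: cutting propyl back to methyl gives a 2.8-fold higher number from compound 3 to compound 4 (0.44 log units; beyond the scatter), so the ethyl portion that leaves does count in this assay. The methyl compound also lands level with the two earlier, weaker compounds, with a 1.4-fold lower number from compound 2 to compound 4 (0.14 log units; within the scatter) and a 1.3-fold higher number from compound 1 to compound 4 (0.12 log units; within the scatter), both steps within the scatter, so methyl, 3-hydroxypropyl and cyclopentyl cannot be told apart here, and compound 3 with its propyl group alone stands out as the strongest inhibitor of growth of the four. Nothing measured here explains why the shorter chain gives the higher number.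

The compounds shown leave open how an ethyl or butyl group would fare on this nitrogen, and so whether propyl is a true optimum among straight chains or longer chains would do as well or better. Also open, going by these compounds, is whether a 3-aminopropyl group or a chain ending in a carboxylic acid would behave like the 3-hydroxypropyl group of compound 2 or like the plain propyl group of compound 3.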